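A few compounds are considered here, and "the series" means these few. Any claim that something is new, unique, unknown or untested is made for them only; others in the source may bear on it.

In a functional assay on CEM-SS cells (Homo sapiens) for cytotoxicity (on this read-out lower numbers stand for stronger inhibition and higher numbers for weaker inhibition), compound 3 `COc1ccc(Cn2c(Cl)nc3cc(Cl)c(Cl)cc32)cc1` stands only at a limit, > 100000 nM. Compound 2 `Clc1ccc(Cn2c(Cl)nc3cc(Cl)c(Cl)cc32)cc1` also gives only a limit, > 100000 nM. Compound 1 `Cc1ccc(Cn2c(N)nc3cc(Cl)c(Cl)cc32)cc1` alone has a number, 40000 nM. Compound 4 `Cc1ccc(Cn2c(Cl)nc3cc(Cl)c(Cl)cc32)cc1` carries methyl in place of methoxy on an aromatic carbon, para to a large group: methyl in place of methoxy on an aromatic carbon. Going by the values given here, the one measured step at that place, a step that the two limits leave unreadable from compound 2 to compound 3, exchanges the group there, but its size cannot be read. What remains is the limit of > 100000 nM in this assay, at which 2 of the 3 values shown sit, so no step beyond the scatter is expected in this assay. The expected step is a number no higher from compound 3 to compound 4 (the limit leaves the size open). Compound 4 is estimated at 100000 nM, with an expected range from 50000 nM to 200000 nM.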

Compound 4, half-maximal inhibitory concentration: > 100000 nM
Compound 4: only a limit was reported; the forecaster's own chance of this, stated with the estimate: 70%; the middle value lies on the limit itself.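

In this assay, methyl now joins chloro and methoxy on the aromatic carbon para to a large group, and compound 2, compound 3 and compound 4 all stand only at limits, so the steps among them cannot be read. Going by these compounds alone, the one readable change lies at another place, where chloro replaces amino and gives an at least 2.5-fold higher number from compound 1 to compound 4 (0.39 log units; beyond the scatter). The picture at this position therefore rests on a single limit: the limit of > 100000 nM in this assay, at which 3 of the 4 values shown sit.

From the compounds shown here alone, it remains open whether a carboxylic acid or an amine on that aromatic carbon would give a number rather than a limit. Going by these compounds, it also remains open whether amino at the other place would give a number with chloro or methoxy in place of methyl.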